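Phenyl for oxetane on the amide nitrogen of compound 1

A few compounds are considered here, and "the series" means these few. Any claim that something is new, unique, unknown or untested is made for them only; others in the source may bear on it.

This account follows a single step from a measured compound to one not yet measured. Compound 1 `Cc1ccc(OCC(=O)N(Cc2cccs2)C2COC2)cc1` was tested in an assay on HEK293 cells for agonist activity at transient receptor potential cation channel subfamily M member 8 (Homo sapiens), read by fluorescence and calcium flux, with a stated time of 15 min (a lower number here means that less compound is needed, a higher number that more compound is needed for the effect), where compound 1 gives 23000 nM. For the measured compounds named here, it is the only compound with a reported number; a second compound, compound 2 `CCN(Cc1cccs1)C(=O)COc1ccc(C(=O)O)cc1`, is recorded in this assay as "not active" (no number reported), without a value attached, so compound 1 stands alone as the reference point and the two cannot be set in order against each other.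

Compound 3 `Cc1ccc(OCC(=O)N(Cc2cccs2)c2ccccc2)cc1` differs from compound 1 in one place: phenyl in place of oxetan-3-yl on an amide-type nitrogen. Going by the values given here, no measured pair in this set shows what such a change does, so the size of the step rests on expectation alone. Given that compound 1 gives 23000 nM, a change from compound 1 to compound 3 of a 1.9-fold lower number from compound 1 to compound 3 (0.28 log units; within the scatter) is estimated, within the usual scatter or a little beyond it. Compound 3 is therefore expected to give about 12000 nM in this assay, with a range from 3000 nM to 50000 nM.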

Compound 3, half-maximal effective concentration: 23 nM
Compound 3: middle estimate off by 520-fold (2.72 log units), on the high side; the whole stated range lies above it.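

In this assay, for the compounds shown here, the group on the amide-type nitrogen turns out to have a very large effect: phenyl in place of oxetan-3-yl gives a 1000-fold lower number from compound 1 to compound 3 (3.00 log units; beyond the scatter) and lies well beyond the scatter, something the earlier compounds could not show because they offered no measured step. The rest of the structure is shared, so this step belongs to the one place where a four-membered non-aromatic ring with 1 hetero atom gives way to a six-membered aromatic ring of carbon only. This single pair cannot separate the contribution of aromaticity from that of ring size or the loss of the ring oxygen, and nothing available here explains the size of the step.

Going by these compounds, it remains open whether a cyclohexyl group, which would keep the six-membered ring without aromaticity, or a pyridyl group, which would put a nitrogen into the aromatic ring, would hold the number near that of compound 3 23 nM in this assay. Equally open, on these data alone, is how far a fluorine or a methoxy group on the new phenyl ring would move it in either direction.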